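Sulfonyl sulfur substituents: from compound 3 to compound 4

The source may report more compounds than this note shows. Statements on the series, on what has been measured and on what is new or still open speak of the compounds shown alone.

Measured so far in a physicochemical assay for solubility, read by HPLC, using the shake flask method, measured as kinetic solubility, with a stated time of 20 h, at pH 6.5, tested at 200 uM; a lower number here means a less soluble compound, a higher number a more soluble compound:
- compound 1 `O=S(=O)(NCC1COC1)c1cccc(-c2ccc3nccc(-c4ccncc4)c3n2)c1`: 20000 nM
- compound 2 `c1cc(-c2ccnc3ccc(NC4CC4)nc23)ccn1`: 90000 nM
- compound 3 `O=S(=O)(CCO)c1cccc(-c2ccc3nccc(-c4ccncc4)c3n2)c1`: 55000 nM

Compound 3 stands within the scatter of compound 2 and well clear of compound 1, so it belongs to the upper part of this small set. The next structure is compound 4 `NS(=O)(=O)c1cccc(-c2ccc3nccc(-c4ccncc4)c3n2)c1`, with amino in place of 2-hydroxyethyl on a sulfonyl sulfur. Within the data shown here, one measured step bears on this change: a 2.8-fold higher number from compound 1 to compound 3 (0.44 log units; beyond the scatter), a modest step in which 2-hydroxyethyl replaced ((oxetan-3-yl)methyl)amino at the same place. Compound 4 also has a nitrogen substituent on that sulfur, so that step, read backwards, suggests a modest drop in this assay. Among the measured compounds shown here, no measured compound carries plain amino there, so the size remains uncertain and the range is kept wide. The expected change is a 2.0-fold lower number from compound 3 to compound 4 (0.29 log units; within the scatter). For compound 4 the estimated value is 28000 nM, with an expected range of 10000 nM to 75000 nM.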

Compound 4, solubility: < 5000 nM
Compound 4 gave a limit, no number; the forecaster's own chance of this, stated with the estimate: 3%; middle value at least 5.6-fold (0.74 log units) from the limit.
By their numbers in this assay, from the lowest: compound 1; then compounds 3 and 2 (each within the scatter of the next). At a limit, below all of these: compound 4.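

In this assay compound 4 stands as a limit, not a number: the limit of < 5000 nM in this assay, at which 1 of the 4 values shown sits. The group on the sulfonyl sulfur proves able to carry a large change, with amino in place of 2-hydroxyethyl giving an at least 11-fold lower number from compound 3 to compound 4 (1.04 log units; beyond the scatter). The sulfonamide nitrogen matters as well, since hydrogen in place of (oxetan-3-yl)methyl gives an at least 4.0-fold lower number from compound 1 to compound 4 (0.60 log units; beyond the scatter), so among the three compounds with a sulfonyl group, the one with the plain sulfamoyl group lies lowest, whether compared with a carbon or a substituted nitrogen substituent on that sulfur.

From the compounds shown here alone, both steps start from a limit, so their full sizes remain open. Also open, going by these compounds, is where a small substituent such as methyl on the sulfonamide nitrogen, or a dimethylamino group on the sulfonyl sulfur, would fall in this assay.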